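Replacing 3-nitrophenyl with 4-cyanophenyl: working notes on compound 3

The source may report more compounds than this note shows. Statements on the series, on what has been measured and on what is new or still open speak of the compounds shown alone.

In a functional assay on SMMC-7721 cells (Homo sapiens) for cytotoxicity, read by MTT assay, with a stated time of 24 h (a higher number here means a weaker inhibitor, a lower number a stronger inhibitor), compound 1 (`COc1cc(/C=C2\CN(S(=O)(=O)c3ccc(NC(C)=O)cc3)C/C(=C\c3ccccc3F)C2=O)cc(OC)c1OC`) gives 3920 nM and compound 2 (`COc1cc(/C=C2\CN(S(=O)(=O)c3ccc(NC(C)=O)cc3)C/C(=C\c3cccc([N+](=O)[O-])c3)C2=O)cc(OC)c1OC`) gives 1950 nM as its number. These two numbers lie within the scatter of each other, so compound 2 cannot be separated from compound 1. Compound 3 (`COc1cc(/C=C2\CN(S(=O)(=O)c3ccc(NC(C)=O)cc3)C/C(=C\c3ccc(C#N)cc3)C2=O)cc(OC)c1OC`) has not yet been measured. Its structural change is 4-cyanophenyl in place of 3-nitrophenyl on a double-bonded chain carbon bound to a double-bonded ring carbon with 4-cyanophenyl in place of 3-nitrophenyl on a double-bonded chain carbon bound to a double-bonded ring carbon. Among the measured compounds shown here, the only measured guide is a 2.0-fold lower number from compound 1 to compound 2 (0.30 log units; within the scatter) at the same place, and on that evidence no step beyond the scatter is expected in this assay for this change. The estimated step is a 1.3-fold higher number from compound 2 to compound 3 (0.11 log units; within the scatter). A single step gives little support for a direction. Compound 3 is expected at 2500 nM (estimated range 1000 nM to 6000 nM).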

Compound 3, half-maximal inhibitory concentration: 1730 nM
Beside the measured number, compound 3's estimate is 1.4-fold (0.16 log units) above it, and the stated range covers the measured number.
By their numbers in this assay, from the lowest: compounds 3, 2 and 1 (each within the scatter of the next, the first and the last beyond it).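

In this assay, 4-cyanophenyl in place of 3-nitrophenyl on a double-bonded chain carbon bound to a double-bonded ring carbon gives a 1.1-fold lower number from compound 2 to compound 3 (0.05 log units; within the scatter) and so leaves these two groups unseparated. Among the compounds shown here, the comparison with the 2-fluorophenyl of compound 1 gives a 2.3-fold lower number from compound 1 to compound 3 (0.36 log units; beyond the scatter) and is the first step at this place to lie beyond the scatter, though only modestly, whereas compound 2 could not be separated from compound 1. No measurement is available that bears on the origin of this difference.

Compound 2 and compound 3 change both the substituent and its numbered ring position, so 3-cyanophenyl and 4-nitrophenyl would be needed to take those two apart. Going by these compounds, how a phenyl carrying an amine or a carboxylic acid would behave at this place also remains open.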